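Methoxy replacing nitro on a benzothiazole ether: what to expect

A few compounds are considered here, and "the series" means these few. Any claim that something is new, unique, unknown or untested is made for them only; others in the source may bear on it.

Measured compounds:
Compound 1, `Cc1ccc(COc2nc3ccccc3s2)cc1`, gives "not active" (no number reported) in a functional assay on the whole organism with Mus musculus as the target, in the writhing test, at a dose of 100 mg/kg by the intraperitoneal route; on this read-out lower numbers stand for less inhibition and higher numbers for more inhibition at the one dose given (going by the name of the read-out).
Compound 2, `O=[N+]([O-])c1ccc(COc2nc3ccccc3s2)cc1`, gives 97% in this assay.

Among the measured compounds shown here, compound 2 holds the only number in the set; compound 1 stands beside it with a result reported in words alone, no number given, so no step between the two can be sized. Within what is known, compound 2 is the one compound with a reading, and that reading is high.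

Compound 3, `COc1ccc(COc2nc3ccccc3s2)cc1`, is the next compound to be tested. The change from compound 2 is methoxy in place of nitro on an aromatic carbon. The group that enters is smaller than the one that leaves, and the count of acceptors falls by one, as the comparison shows.

For the measured compounds named here, no step between measured compounds is available, so the expectation rests on the two readings alone. Compound 1, which also carries a small group at the same place, gave no number, while compound 2 gave a high reading. The expected step from compound 2 to compound 3 is estimated at a number 67 percentage points lower from compound 2 to compound 3 (beyond the scatter), a drop beyond the scatter. Compound 3 is therefore expected to give about 30%, with a range from 0% to 75%.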

Compound 3, a percentage reported as inhibition, in the whole organism at one dose (the size of the read-out at that dose, not a potency): "not active" (no number reported)
Compound 3: no number reported, and the estimate cannot be compared.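

Among the compounds shown here, compound 3, like compound 1, has its result in this assay reported in words without a number, so no step from compound 2 to compound 3 can be read. Nothing shown here offers an explanation for this result. The compounds shown leave open how far compound 3 lies from compound 2, and whether compound 1 and compound 3 differ at all.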